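Lengthening the Hydroxycarbamoyl Chain of Compound 2

The source may hold more compounds than are shown below. What is called first, only, known or untested is meant among the compounds shown, and "the series" means these compounds.

Of the compounds shown here, three have been measured so far in a functional assay on MCF7 cells (Homo sapiens) for inhibition, read by MTT assay (on this read-out higher numbers stand for weaker inhibition and lower numbers for stronger inhibition), and each ends in a hydroxycarbamoyl group. Compound 2 (`CC(C)=CCC/C(C)=C/CC/C(C)=C/CSc1ccccc1C(=O)NCCC(=O)NO`) gives 4930 nM which is the highest number of the three and beyond the scatter from both others, so it is the weakest inhibitor here. Compound 1 (`O=C(CCCCCCC(=O)Nc1nnc(-c2ccco2)s1)NO`) gives 880 nM and compound 3 (`O=C(COc1ccc(C(=O)/C=C/c2ccc(F)cc2)cc1)NO`) gives 620 nM and these two lie within the scatter of each other.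

Compound 4 (`CC(C)=CCC/C(C)=C/CC/C(C)=C/CSc1ccccc1C(=O)NCCCC(=O)NO`) is compound 2 changed in one place: (hydroxycarbamoyl)methyl in place of hydroxycarbamoyl on a saturated chain carbon, two bonds along the chain from an amide-type nitrogen with (hydroxycarbamoyl)methyl in place of hydroxycarbamoyl on a saturated chain carbon, two bonds along the chain from an amide-type nitrogen. Within the data shown here, no measured pair differs in just one place, so this assay offers no direct guide to this change. The only hint is loose: compound 1 carries its hydroxycarbamoyl on a longer saturated chain and gives 880 nM but the rest of its structure differs as well. The expected change is a modest one towards stronger inhibition, estimated as a 2.2-fold lower number from compound 2 to compound 4 (0.35 log units; beyond the scatter) and only a little beyond the scatter. For compound 4 the estimated value is 2200 nM with an expected range from 800 nM to 5500 nM in this measurement.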

Compound 4, half-maximal inhibitory concentration: 4930 nM
The estimate for compound 4 lay 2.2-fold (0.35 log units) below the measured number; the measured number falls inside the stated range.
By their numbers in this assay, from the lowest: compounds 3 and 1 (each within the scatter of the next); then compounds 2 and 4 (each within the scatter of the next).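

In this assay, putting (hydroxycarbamoyl)methyl in place of hydroxycarbamoyl on a saturated chain carbon, two bonds along the chain from an amide-type nitrogen, gives no change at the digits printed from compound 2 to compound 4 (within the scatter). This is the only pair shown that differs in one place, so it offers the first direct reading of this position: the lengthening is tolerated, but it brings no measurable gain in inhibition. Nothing shown explains why the number stays where it is.

As far as these compounds go, this single step cannot show how the chain behaves over a wider range, so it remains open whether a longer chain, such as 2-(hydroxycarbamoyl)ethyl or 3-(hydroxycarbamoyl)propyl at the same place, would shift the number or leave it unchanged. From the compounds shown here alone, it is also open how much the hydroxycarbamoyl group itself contributes at this position, which a carboxylic acid in its place on the same chain would test directly.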